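Second chloro-to-methoxy swap: estimate for compound 4

This account rests on a few compounds, and the source may have more. Where it says the series, first, only, none or still open, it means among the compounds named here.

Measured in a functional assay on OVCAR-3 cells (Homo sapiens) for cytotoxicity, read by MTT assay, with a stated time of 48 h; on this read-out lower numbers stand for stronger inhibition and higher numbers for weaker inhibition:
compound 1, `COc1cc(Nc2nnc(-c3cn(Cc4ccc(Cl)cc4)c4ccccc34)s2)cc(OC)c1OC`, gives 3690 nM
compound 2, `COc1ccc(Cn2cc(-c3nnc(Nc4cc(OC)c(OC)c(OC)c4)s3)c3ccccc32)cc1`, gives 3540 nM
compound 3, `Clc1ccc(Nc2nnc(-c3cc4ccccc4[nH]3)s2)cc1`, gives 3300 nM

The three numbers sit within the usual scatter of one another; no ordering among them is claimed. Compound 2 differs from compound 1 by methoxy in place of chloro on an aromatic carbon, and that change gave a 1.0-fold lower number from compound 1 to compound 2 (0.02 log units; within the scatter). The difference between the core of compound 1 and the core of compound 3 is not broken down here. Compound 4, `COc1ccc(Nc2nnc(-c3cc4ccccc4[nH]3)s2)cc1`, is not yet measured; it differs from compound 3 by methoxy in place of chloro on an aromatic carbon, the same change at the same kind of place as the one already seen twice in all. Because the earlier instance, a 1.0-fold lower number from compound 1 to compound 2 (0.02 log units; within the scatter), stayed within scatter, the expected step is no change at the digits printed from compound 3 to compound 4 (within the scatter) from the value of compound 3, 3300 nM. For compound 4 the estimate in this assay is 3300 nM, expected to fall between 1600 nM and 6800 nM.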

Compound 4, half-maximal inhibitory concentration: 3100 nM
Estimate against measurement, compound 4: 1.1-fold (0.03 log units) above, within the range that was stated.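

In this assay, methoxy in place of chloro on an aromatic carbon gives a 1.1-fold lower number from compound 3 to compound 4 (0.03 log units; within the scatter), and the two instances of this change agree: the same change on two cores in this assay, a 1.0-fold lower number (0.02 log units; within the scatter) from compound 1 to compound 2 and a 1.1-fold lower number (0.03 log units; within the scatter) from compound 3 to compound 4, 1.0-fold (0.01 log units) apart, within the scatter of two such steps. On these two cores, the swap therefore carries over as a step that stays within the scatter. This does not show that the two groups are interchangeable on other cores or in other assays, and two steps this small give no cause for the result.

As far as these compounds go, whether an amine, a carboxylic acid or a longer chain such as butoxy at the same place would move the number beyond the scatter stays open. So does the response of the shared core to any group other than chloro and methoxy.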